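Trading methyl for trifluoromethyl in a cytotoxic series

The compounds below may be only part of what the source reports. "The series", "measured", "known", "first", "only" and "open" are said of these compounds alone.

For the measured compounds named here, in a functional assay on 143B cells (Homo sapiens) for cytotoxicity (on this read-out lower numbers stand for higher toxicity in this test and higher numbers for lower toxicity in this test), compound 2 `Cc1cn([C@H]2C[C@H](Oc3no[n+]([O-])c3S(=O)(=O)c3ccccc3)[C@@H](CO)O2)c(=O)[nH]c1=O` gives 880 nM, the lower of the two numbers so far, while compound 1 `O=c1ccn([C@H]2C[C@H](Oc3no[n+]([O-])c3S(=O)(=O)c3ccccc3)[C@@H](CO)O2)c(=O)[nH]1` gives 2900 nM. Compound 3 `O=c1[nH]c(=O)n([C@H]2C[C@H](Oc3no[n+]([O-])c3S(=O)(=O)c3ccccc3)[C@@H](CO)O2)cc1C(F)(F)F` differs from compound 2 by one change: trifluoromethyl in place of methyl on an aromatic carbon. Going by the values given here, only one measured step bears on this, a 3.3-fold lower number from compound 1 to compound 2 (0.52 log units; beyond the scatter), which was modest but beyond the scatter and came from methyl replacing hydrogen on an aromatic carbon. It does not show how trifluoromethyl compares with methyl, so no clear direction can be argued. In this assay, the expected result is no shift beyond the scatter, with an estimated 1.1-fold higher number from compound 2 to compound 3 (0.06 log units; within the scatter). For compound 3, the estimated value is 1000 nM, within a range of 350 nM to 3000 nM.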

Compound 3, half-maximal cytotoxic concentration: 480 nM
Compound 3: the middle estimate sits 2.1-fold (0.32 log units) above what was measured, and the stated range covers the measured number.
By their numbers in this assay, from the lowest: compounds 3 and 2 (each within the scatter of the next); then compound 1.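

In this assay, trifluoromethyl in place of methyl on this aromatic carbon gives a 1.8-fold lower number from compound 2 to compound 3 (0.26 log units; within the scatter) and so cannot be told apart from methyl here, despite its extra heavy atoms. Measured against hydrogen, the same group gives a 6.0-fold lower number from compound 1 to compound 3 (0.78 log units; beyond the scatter) and so joins methyl on the lower side of hydrogen. Nothing available explains this result. Still open, going by these compounds, is whether the lower numbers depend on carbon-bearing groups at this position. A longer chain, an amine or a carboxylic acid there could test this.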